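Acetylating the amino group of compound 2

The compounds below may be only part of what the source reports. "The series", "measured", "known", "first", "only" and "open" are said of these compounds alone.

In a functional assay on PC-3 cells (Homo sapiens) for cytotoxicity, read by MTT assay, with a stated time of 48 h (on this read-out lower numbers stand for stronger inhibition and higher numbers for weaker inhibition), compound 1 `COc1ccc(-c2c(-c3cc(OC)c(OC)c(OC)c3)noc2N)cc1` gives 3030 nM. Compound 2 `COc1ccc(-c2c(-c3cc(OC)c(OC)c(OC)c3)noc2N)cc1OC` gives 21100 nM, the higher of the two numbers in the series. Compound 3 `COc1cc(-c2noc(N)c2-c2ccc(Cl)cc2)cc(OC)c1OC` gives > 50000 nM, which is a limit of the assay and not a number.

Next for measurement is compound 4 `COc1ccc(-c2c(-c3cc(OC)c(OC)c(OC)c3)noc2NC(C)=O)cc1OC`. The change is acetyl in place of hydrogen on a nitrogen on an aromatic ring, or amino to acetamido.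

Neither measured step touches that nitrogen. Both lie on an aromatic carbon: methoxy in place of hydrogen gives a 7.0-fold higher number from compound 1 to compound 2 (0.84 log units; beyond the scatter), and chloro in place of methoxy gives an at least 16-fold higher number from compound 1 to compound 3 (1.21 log units; beyond the scatter). Both go towards higher numbers, and the second ends at a limit, so they offer only indirect guidance on direction and none on this specific change. On that weak basis, a modest move towards a higher number is expected in this assay, with a real chance that compound 4 also returns only a limit.

The expected change is a 1.5-fold higher number from compound 2 to compound 4 (0.18 log units; within the scatter). The estimated value for compound 4 is 32000 nM, with an expected range from 10000 nM to 50000 nM.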

Compound 4, half-maximal inhibitory concentration: > 50000 nM
Compound 4 gave a limit, no number; the forecaster's own chance of this, stated with the estimate: 35%; middle value at least 1.5-fold (0.19 log units) from the limit.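

Among these compounds, until now, every measured step lay on an aromatic carbon, so this is the first reading on the amino nitrogen itself. In this assay, acetyl in place of hydrogen on that nitrogen gives an at least 2.3-fold higher number from compound 2 to compound 4 (0.37 log units; beyond the scatter), so amino to acetamido does not preserve even the weak activity of compound 2 on this read-out. The step is only a lower bound and its true size stays unknown, because compound 4 sits at the limit of the assay and gives no number: the limit of > 50000 nM in this assay, at which 2 of the 4 values shown sit.

Going by these compounds, it remains open whether this loss is specific to acetyl or extends to other replacements of hydrogen on this nitrogen, such as a methyl group, a formyl group or a longer acyl chain like propionyl. Also open, on these data alone, is whether amino to acetamido has the same outcome on the core of compound 1, where the starting point leaves more room below the limit for a step to be read as a number.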